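Compound 3 to compound 4: methyl to ethyl

The source may hold more compounds than are shown below. What is called first, only, known or untested is meant among the compounds shown, and "the series" means these compounds.

In a functional assay on the whole organism (Myocardium) with Canis familiaris (Canis lupus familiaris) as the target (on this read-out higher numbers stand for an effect only at larger amounts of compound and lower numbers for an effect already at smaller amounts), compound 1 (`CC1C(=O)NN=C1c1ccc(-n2ccnc2)cc1`) gives > 1 mg/kg and this is a limit. Compound 2 (`CCC1C(=O)NN=C1c1ccc(-n2ccnc2)cc1`) gives > 1 mg/kg and this too is a limit. Among the measured compounds shown here, compound 3 (`CC1(C)C(=O)NN=C1c1ccc(-n2ccnc2)cc1`) gives 0.18 mg/kg and this is the only true number of the three.

Compound 4 (`CCC1(C)C(=O)NN=C1c1ccc(-n2ccnc2)cc1`) follows from compound 3 by one change (methyl in place of hydrogen on a saturated chain carbon bound to a saturated ring carbon) that turns methyl to ethyl. The same replacement in the same place appears in a step that the two limits leave unreadable from compound 1 to compound 2 and so offers no size to carry over. The other measured step is an at least 5.5-fold lower number from compound 1 to compound 3 (0.74 log units; beyond the scatter) but it put methyl in place of hydrogen on a saturated ring carbon, which is a different place. Neither step fixes the size here, so only a slight rise in the number is expected. The expected step is a 1.7-fold higher number from compound 3 to compound 4 (0.22 log units; within the scatter) in this assay and it is estimated to stay within the scatter. The estimated value for compound 4 is 0.3 mg/kg with 0.1 mg/kg as the expected lower end and 1 mg/kg as the upper end.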

Compound 4, dose for half-maximal effect: 0.37 mg/kg
Beside the measured number, compound 4's estimate is 1.2-fold (0.09 log units) below it; the range from low to high includes it.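

Among the compounds shown here, the change from methyl to ethyl now has a readable size for the first time: in this assay it is a 2.1-fold higher number from compound 3 to compound 4 (0.31 log units; beyond the scatter). Even with the longer group, a second substituent on the saturated ring carbon still goes with a lower number, as seen in an at least 2.7-fold lower number from compound 2 to compound 4 (0.43 log units; beyond the scatter) and in an at least 2.7-fold lower number from compound 1 to compound 4 (0.43 log units; beyond the scatter). Methyl in place of hydrogen on a saturated ring carbon therefore lowers the number on two cores, though the sizes cannot be set against each other: the same change on two cores in this assay, an at least 5.5-fold lower number (0.74 log units; beyond the scatter) from compound 1 to compound 3 and an at least 2.7-fold lower number (0.43 log units; beyond the scatter) from compound 2 to compound 4; the limit leaves it open whether they differ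

The compounds shown leave open whether a longer chain, such as propyl, on the same ring carbon would raise the number further in this assay. They also leave open how a hydroxyl or an amine at the end of that chain would read there.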